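Swapping the aryl group on the triazole nitrogen

This account rests on a few compounds, and the source may have more. Where it says the series, first, only, none or still open, it means among the compounds named here.

Compound 1 `Cc1ccccc1-n1cc(-c2cccc(NS(=O)(=O)c3c[nH]c(=O)[nH]c3=O)c2)nn1` gives 15300 nM in an ADME assay on L02 cells (Homo sapiens) for cytotoxicity, read by MTT assay, with a stated time of 24 h; a higher number here means that more compound is tolerated, a lower number that less compound is tolerated.
Compound 2 `Cc1ccc(-n2cc(-c3cccc(NS(=O)(=O)c4c[nH]c(=O)[nH]c4=O)c3)nn2)cc1` gives 23100 nM in this assay.

Among the compounds with values here, compound 2 stands as the higher of the two numbers measured so far, but its only neighbour, compound 1, lies close: a 1.5-fold higher number from compound 1 to compound 2 (0.18 log units; within the scatter). The next compound, compound 3 `O=c1[nH]cc(S(=O)(=O)Nc2cccc(-c3cn(-c4cccc(F)c4)nn3)c2)c(=O)[nH]1`, has not yet been measured. It differs from compound 2 in one place: 3-fluorophenyl in place of 4-methylphenyl on an aromatic nitrogen. Within the data shown here, no measured step changes the aryl group on the aromatic nitrogen in this way, so the one step that exists, from compound 1 to compound 2, is only a loose guide; it moved a methyl on that ring and stayed within the scatter. On that basis no step beyond the scatter is expected here either, so compound 3 is estimated at 19000 nM in this assay, with a likely range from 7000 nM to 50000 nM. That estimate means a step of a 1.2-fold lower number from compound 2 to compound 3 (0.08 log units; within the scatter), which is expected to sit inside the usual scatter.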

Compound 3, half-maximal cytotoxic concentration: "not toxic" (no number reported)
Nothing numeric was reported for compound 3; no gap can be computed for the estimate.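

Within the data shown here, compound 3 is reported only as "not toxic" in this assay, with no number, so no step from compound 2 to compound 3 can be read. Nothing shown bears on the reason for that result. The compounds shown leave open how far 3-fluorophenyl and 4-methylphenyl differ in this read-out.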